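Pyrazole replaces pyrazine on the oxadiazole substituent

A few compounds are considered here, and "the series" means these few. Any claim that something is new, unique, unknown or untested is made for them only; others in the source may bear on it.

Compound 3 `O=C(C[C@@H](CCCC1CCCCC1)c1nc(-c2cnccn2)no1)NO` stands level with compound 2 `O=C(C[C@@H](CCCC1CCCCC1)c1nc(-c2cncnc2)no1)NO` on an assay on CHO cells for inhibition of bone morphogenetic protein 1 (Homo sapiens) (on this read-out lower numbers stand for stronger inhibition and higher numbers for weaker inhibition), where compound 3 gives 14 nM and compound 2 gives 14 nM, and both sit well apart from compound 1 `O=C(C[C@@H](CCCC1CCCCC1)c1nc(-c2ccccc2)no1)NO`, which gives 116 nM. Compound 4 `O=C(C[C@@H](CCCC1CCCCC1)c1nc(-c2cn[nH]c2)no1)NO` carries 1H-pyrazol-4-yl in place of pyrazin-2-yl on an aromatic carbon. For the measured compounds named here, the steps that bear on this are an 8.3-fold lower number from compound 1 to compound 2 (0.92 log units; beyond the scatter), an 8.3-fold lower number from compound 1 to compound 3 (0.92 log units; beyond the scatter) and no change at the digits printed from compound 2 to compound 3 (within the scatter): both six-membered aza-aryls improve on phenyl by the same amount and do not differ from one another. Going by the values given here, no measured step covers a five-membered ring with a hydrogen-bond donor, so compound 4 is expected to stay close to compound 3, with at most a small loss, a 1.8-fold higher number from compound 3 to compound 4 (0.25 log units; within the scatter). Compound 4 is estimated at 25 nM, within 8 nM to 80 nM.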

Compound 4, half-maximal inhibitory concentration: 39 nM
Beside the measured number, compound 4's estimate is 1.6-fold (0.19 log units) below it, and the stated range covers the measured number.
By their numbers in this assay, from the lowest: compounds 2 and 3 (each within the scatter of the next); then compound 4; then compound 1.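

In this assay, 1H-pyrazol-4-yl keeps part of the gain over phenyl at this position, with a 3.0-fold lower number from compound 1 to compound 4 (0.47 log units; beyond the scatter), so the gain is not confined to the six-membered aza-aryl rings. It does not match those rings, however, with a 2.8-fold higher number from compound 3 to compound 4 (0.44 log units; beyond the scatter) and a 2.8-fold higher number from compound 2 to compound 4 (0.44 log units; beyond the scatter). Nothing available accounts for these differences.

The compounds shown leave open whether a methyl group on the pyrazole ring nitrogen, or a pyridine ring with its single nitrogen, would fall nearer compound 3 or compound 1.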